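Triazole substituent in the series: from hydrogen to 2-hydroxyethyl

The source may hold more compounds than are shown below. What is called first, only, known or untested is meant among the compounds shown, and "the series" means these compounds.

Compound 1 `O=C1O[C@H]([C@@H](O)Cn2cc(-c3ccc(Br)cc3)nn2)C(OCc2ccccc2)=C1OCc1ccccc1` – 3910 nM
Compound 2 `O=C1O[C@H]([C@@H](O)Cn2ccnn2)C(OCc2ccccc2)=C1OCc1ccccc1` – > 100000 nM (a limit)

Both values come from a functional assay on HeLa cells (Homo sapiens) for antiproliferative activity, read by MTT assay, with a stated time of 72 h; on this read-out higher numbers stand for weaker inhibition and lower numbers for stronger inhibition. Compound 2 gives no number, only a limit: the limit of > 100000 nM in this assay, at which 1 of the 2 values shown sits. Compound 3 `O=C1O[C@H]([C@@H](O)Cn2cc(CCO)nn2)C(OCc2ccccc2)=C1OCc1ccccc1` carries 2-hydroxyethyl in place of hydrogen on an aromatic carbon of the five-membered aromatic ring with 3 nitrogen (2-hydroxyethyl in place of hydrogen on an aromatic carbon). Among the compounds with values here, one measured step bears on this carbon: an at least 25-fold higher number from compound 1 to compound 2 (1.40 log units; beyond the scatter). Read in reverse, that large step shows a substituent here bringing much stronger inhibition, but it comes from 4-bromophenyl, whereas 2-hydroxyethyl has no ring. Only a modest move towards lower numbers is therefore expected in this assay, and another limit would be no surprise. The expected change is an at least 2.0-fold lower number from compound 2 to compound 3 (0.30 log units; that floor lies within the scatter). Compound 3 is estimated at 50000 nM, with an expected range of 10000 nM to 150000 nM.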

Compound 3, half-maximal inhibitory concentration: 68800 nM
Beside the measured number, compound 3's estimate is 1.4-fold (0.14 log units) below it; the range from low to high includes it.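

In this assay, 2-hydroxyethyl on this aromatic carbon gives a measured number rather than a limit, but the comparison with hydrogen yields only a floor: an at least 1.4-fold lower number from compound 2 to compound 3 (0.16 log units; that floor lies within the scatter). Compound 2 has a limit and not a number: the limit of > 100000 nM in this assay, at which 1 of the 3 values shown sits. The clearer comparison at this carbon is with 4-bromophenyl, and it shows that 2-hydroxyethyl does not match that group in this read-out: an 18-fold higher number from compound 1 to compound 3 (1.25 log units; beyond the scatter).

On these data alone, it remains open whether the stronger inhibition with 4-bromophenyl depends on the ring or on the bromine, which unsubstituted phenyl and 4-chlorophenyl could help separate. As far as these compounds go, it is also open whether a butyl chain without the hydroxyl, or a 2-aminoethyl chain, would differ from 2-hydroxyethyl at this carbon.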